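Aryl amine substituent swap: amide to 4-methylpiperidine

The compounds below may be only part of what the source reports. "The series", "measured", "known", "first", "only" and "open" are said of these compounds alone.

Working notes on three measured compounds and one open position. Compound 1 `CC1CCN(c2ccc(Nc3nccc(-c4cccs4)n3)cc2)CC1` gives 400 nM in a functional assay for inhibition, with Homo sapiens as the target; on this read-out higher numbers stand for weaker inhibition and lower numbers for stronger inhibition. Compound 2 `CCc1ccc(Nc2nccc(-c3ccncc3)n2)cc1` gives 7700 nM in this assay. Among the compounds with values here, compound 3 `CC(=O)N(C)c1ccc(Nc2nccc(-c3ccncc3)n2)cc1` gives 500 nM in this assay; on the numbers so far it sits second highest of three, with compound 1 within the scatter and compound 2 well beyond it. Within the data shown here, the one measured step on this core, a 15-fold lower number from compound 2 to compound 3 (1.19 log units; beyond the scatter), shows that the group at this position can move the number a long way.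

Compound 4 `CC1CCN(c2ccc(Nc3nccc(-c4ccncc4)n3)cc2)CC1` is not yet measured. It differs from compound 3 in this way: 4-methylpiperidin-1-yl in place of acetyl(methyl)amino on an aromatic carbon. Among the measured compounds shown here, no measured step covers this exact exchange; compound 1 carries the same 4-methylpiperidin-1-yl group on a different core and its value of 400 nM sits within the scatter of compound 3. The step from compound 3 to compound 4 is therefore expected to be small, a 1.1-fold lower number from compound 3 to compound 4 (0.05 log units; within the scatter), with no clear direction beyond the scatter. Compound 4 is estimated at 450 nM in this assay, within a range of 150 nM to 1400 nM.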

Compound 4, half-maximal inhibitory concentration: 600 nM
Estimate against measurement, compound 4: 1.3-fold (0.12 log units) below, within the range that was stated.
By their numbers in this assay, from the lowest: compounds 1, 3 and 4 (each within the scatter of the next); then compound 2.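

In this assay the exchange of acetyl(methyl)amino for 4-methylpiperidin-1-yl on the shared core gives a 1.2-fold higher number from compound 3 to compound 4 (0.08 log units; within the scatter) and so leaves the number unmoved, which shows that the carbonyl of the amide is not required on this core for a number of this size. Ethyl now stands apart at this position, since a 13-fold lower number from compound 2 to compound 4 (1.11 log units; beyond the scatter) is a second large step alongside a 15-fold lower number from compound 2 to compound 3 (1.19 log units; beyond the scatter) and comes from a group that shares with the amide only the nitrogen on the aromatic carbon. With 4-methylpiperidin-1-yl held fixed, a 1.5-fold higher number from compound 1 to compound 4 (0.18 log units; within the scatter) shows that pyridin-4-yl and thiophen-2-yl are not told apart here.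

From the compounds shown here alone, whether a primary amine, a morpholine ring or a carboxylic acid at this position would hold the number stays open, as does whether the attached nitrogen matters at all. Nothing at hand explains why ethyl stands apart.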